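Adding an acetylsulfamoyl group to a weak growth inhibitor

The source may report more compounds than this note shows. Statements on the series, on what has been measured and on what is new or still open speak of the compounds shown alone.

Measured compounds:
compound 1 `Oc1ccc(O)c(-c2cc(-c3ccccc3)nn2-c2ccccc2)c1`: 75300 nM
compound 2 `Oc1ccc(O)c(-c2cc(-c3ccc(Cl)cc3)nn2-c2ccccc2)c1`: 60400 nM

In a functional assay on cells (Cancer cell lines, Homo sapiens) for cytotoxicity, read by sulforhodamine B assay, with a stated time of 48 h (on this read-out lower numbers stand for stronger inhibition of growth and higher numbers for weaker inhibition of growth), compound 1 gives 75300 nM, the highest of the two numbers; compound 2 gives 60400 nM, and a 1.2-fold lower number from compound 1 to compound 2 (0.10 log units; within the scatter) lies within the scatter. Compound 3 `CC(=O)NS(=O)(=O)c1ccc(-n2nc(-c3ccccc3)cc2-c2cc(O)ccc2O)cc1` differs from compound 1 by acetylsulfamoyl in place of hydrogen on an aromatic carbon. For the measured compounds named here, no measured step touches this position; the only step known, from compound 1 to compound 2, changed a different ring and stayed within the scatter. Compound 3 is therefore expected to stay near compound 1, with a 1.3-fold lower number from compound 1 to compound 3 (0.10 log units; within the scatter) as the estimate. Compound 3 is expected at 60000 nM, between 20000 nM and 180000 nM.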

Compound 3, concentration for total growth inhibition: 100000 nM
Beside the measured number, compound 3's estimate is 1.7-fold (0.22 log units) below it; measured number inside the range.
By their numbers in this assay, from the lowest: compounds 2, 1 and 3 (each within the scatter of the next).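

In this assay, for the compounds shown here, the step of a 1.3-fold higher number from compound 1 to compound 3 (0.12 log units; within the scatter) is the only one measured on this ring, where the earlier compounds showed a chloro change on a different ring. It shows that this position, para to a large group, can carry the whole acetylsulfamoyl group in place of hydrogen with no shift in growth inhibition beyond the scatter. No measurement here offers an explanation for this result. As far as these compounds go, whether an amine or a carboxylic acid at the same position would move the number beyond the scatter remains open.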